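One ring exchange on compound 2 and its expected lipophilicity

The compounds below may be only part of what the source reports. "The series", "measured", "known", "first", "only" and "open" are said of these compounds alone.

Compound 2 `Cc1cc(C)c(CN2CCc3c(Cl)cc(-c4c(C)noc4C)c(Cl)c3C2=O)c(=O)[nH]1` is the most lipophilic of the three compounds measured in a physicochemical assay for lipophilicity, at pH 7.4 (a higher number here means a more lipophilic compound, a lower number a more polar compound), giving 3.1. Compound 1 `Cc1cc(C)c(CN2CCc3c(C)cc(O[C@@H]4CCOC4)c(Cl)c3C2=O)c(=O)[nH]1` gives 2.1, and compound 3 `CCOc1cccc(C(=O)NCc2c(C)cc(C)[nH]c2=O)c1C` gives 2.1; both lie below compound 2 by more than the usual scatter.

Compound 4 `Cc1cc(C)c(CN2CCc3c(Cl)cc(-c4c(C)n[nH]c4C)c(Cl)c3C2=O)c(=O)[nH]1` has not yet been measured. It differs from compound 2 in one place: 3,5-dimethyl-1H-pyrazol-4-yl in place of 3,5-dimethyl-1,2-oxazol-4-yl on an aromatic carbon. The leaving ring counts no hydrogen-bond donor, the entering ring counts one. Going by the values given here, no measured pair here shows this exchange, so the expectation rests on compound 2 alone. A moderate drop in this assay is expected, a step beyond the scatter a number 0.70 log units lower from compound 2 to compound 4 (beyond the scatter). Compound 4 is therefore estimated at 2.4, within a range from 1.9 to 2.9.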

Compound 4, distribution coefficient: 3.4
Beside the measured number, compound 4's estimate is 1.00 log units below it; the whole stated range lies below it.
By their numbers in this assay, from the lowest: compounds 1 and 3 (each within the scatter of the next); then compounds 2 and 4 (each within the scatter of the next).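

In this assay, the exchange of 3,5-dimethyl-1,2-oxazol-4-yl for 3,5-dimethyl-1H-pyrazol-4-yl on this aromatic carbon gives a number 0.30 log units higher from compound 2 to compound 4 (within the scatter) and so does not separate the two rings. At this position, then, a ring counting one hydrogen-bond donor reads the same, within the scatter, as a ring counting none. No measurement here offers an explanation for this result.

On these data alone, whether the exchange behaves alike on another core stays open, since compounds 1 and 3 carry neither ring. As far as these compounds go, how this assay responds to an amine or a carboxylic acid on this aromatic carbon also remains open.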